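A few compounds are considered here, and "the series" means these few. Any claim that something is new, unique, unknown or untested is made for them only; others in the source may bear on it.

Compound 1 `CN(C)C(=O)c1cc2cnc(Nc3ccc(NC(=O)C4(C(=O)Nc5ccc(F)cc5)CC4)cc3)nc2n1C1CCCC1`: 90.8%
Compound 2 `CN(C)C(=O)c1cc2cnc(Nc3ccc(NC(=O)C4(C(=O)Nc5ccc(Cl)cc5)CC4)cc3)nc2n1C1CCCC1`: 88.6%

In a functional assay on NCI-H1299 cells (Homo sapiens) for inhibition, read by CCK-8 assay, with a stated time of 72 h, tested at 10 uM (a lower number here means less inhibition of growth, a higher number more inhibition of growth at the concentration tested), compound 2 stands at 88.6%, within the scatter of compound 1. Compound 3 `CN(C)C(=O)c1cc2cnc(Nc3ccc(NC(=O)C4(C(=O)Nc5cccc(F)c5)CC4)cc3)nc2n1C1CCCC1` carries 3-fluorophenyl in place of 4-chlorophenyl on an amide-type nitrogen. Going by the values given here, one measured step bears on this change, a number 2.2 percentage points lower from compound 1 to compound 2 (within the scatter), where chloro replaces fluoro on an aromatic carbon, and it stays within the scatter. Among the compounds with values here, no measured compound carries the 3-fluorophenyl group, so this expectation is uncertain. The expected change is a number 1.6 percentage points lower from compound 2 to compound 3 (within the scatter), meaning no step beyond the scatter in either direction. Compound 3 is estimated at 87%, with an expected range of 72% to 96%.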

Compound 3, percent growth inhibition at one concentration: 87%
Beside the measured number, compound 3's estimate shows no gap at the digits printed, and the stated range covers the measured number.
By their numbers in this assay, from the lowest: compounds 3, 2 and 1 (each within the scatter of the next).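

In this assay, 3-fluorophenyl on the amide-type nitrogen gives a number 1.6 percentage points lower from compound 2 to compound 3 (within the scatter), and a number 3.8 percentage points lower from compound 1 to compound 3 (within the scatter). The earlier compounds shown here showed only one halogen exchanged for another, whereas compound 1 and compound 3 show that 4-fluorophenyl and 3-fluorophenyl also cannot be told apart in this measurement. Nothing available explains this result. Still open, going by these compounds, is whether plain phenyl, an aminophenyl or a carboxyphenyl group on this nitrogen would hold growth inhibition at the same level. Cyclohexyl, which has no aromatic ring, is equally open.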